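Swapping the nitrile for bromine on the shared core

A few compounds are considered here, and "the series" means these few. Any claim that something is new, unique, unknown or untested is made for them only; others in the source may bear on it.

Compound 1 `C/N=C(/S)C1=CC(C)(C)Oc2ccc(C#N)cc21` sits in the middle of three measured compounds in a functional assay (aorta) with Rattus norvegicus as the target; on this read-out lower numbers stand for an effect already at smaller amounts and higher numbers for an effect only at larger amounts of compound: compound 1 gives 24.6 nM. Compound 2 `C/N=C(/S)C1=CC(C)(C)Oc2ccc(S(C)(=O)=O)cc21` gives 457 nM in this assay, a change of a 19-fold higher number from compound 1 to compound 2 (1.27 log units; beyond the scatter). Compound 3 `C/N=C(/S)C1=CC(C)(C)Oc2ccc(OC(F)(F)F)cc21` gives 4.07 nM, a change of a 6.0-fold lower number from compound 1 to compound 3 (0.78 log units; beyond the scatter). Between those two, the move is a 110-fold lower number from compound 2 to compound 3 (2.05 log units; beyond the scatter). So the single aromatic position that varies across these compounds already spans a wide stretch of numbers, in both directions from compound 1.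

Compound 4 `C/N=C(/S)C1=CC(C)(C)Oc2ccc(Br)cc21` has not yet been tested. It differs from compound 1 in one place: bromo in place of cyano on an aromatic carbon. Both earlier replacements at this position bear on the step, but neither installed a bromine, so they show only that the position matters, not where a bromine will land. With one replacement pulling the number down and the other pushing it up, the reasonable expectation for compound 4 is a step of a 1.6-fold lower number from compound 1 to compound 4 (0.21 log units; within the scatter), a change close to or within the usual scatter rather than a large shift. Compound 4 is therefore estimated at 15 nM, with a plausible range from 4 nM to 60 nM.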

Compound 4, half-maximal effective concentration: 9.33 nM
Estimate against measurement, compound 4: 1.6-fold (0.21 log units) above; the range from low to high includes it.
By their numbers in this assay, from the lowest: compound 3; then compound 4; then compound 1; then compound 2.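

In this assay the change to bromine gives a 2.6-fold lower number from compound 1 to compound 4 (0.42 log units; beyond the scatter) and so shows that a single bromine atom, counted with no hydrogen-bond acceptor, can replace the two-atom nitrile and still give a lower number. The nitrile's acceptor is therefore not required for a low number at this position, although the bromo compound does not match the trifluoromethoxy compound: swapping that group for bromine gives a 2.3-fold higher number from compound 3 to compound 4 (0.36 log units; beyond the scatter) on the same read-out, while the replacement of methylsulfonyl by bromine gives a 49-fold lower number from compound 2 to compound 4 (1.69 log units; beyond the scatter) and places bromine much closer to the low end of the series. These steps all lie beyond the usual scatter, so the four groups now form a clear order, but no measurement shown here explains why they fall in that order.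

The compounds shown leave open how an amine, a carboxylic acid or a longer chain such as a butyl group would read at this aromatic carbon, and whether a plain hydrogen there would give a higher or lower number than bromine. They also leave open whether the same order of groups would hold if another part of the shared core changed.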